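This account rests on a few compounds, and the source may have more. Where it says the series, first, only, none or still open, it means among the compounds named here.

Measured so far in a functional assay on SMMC-7721 cells (Homo sapiens) for antiproliferative activity, read by CCK-8 assay, with a stated time of 72 h; on this read-out higher numbers stand for weaker inhibition and lower numbers for stronger inhibition:
- compound 1 `Nc1ccccc1NC(=O)c1ccc(CSCCc2ccccc2)cc1`: 4880 nM
- compound 2 `Nc1ccccc1NC(=O)c1ccc(CSc2ccc(F)cc2)cc1`: 5770 nM
- compound 3 `Nc1ccccc1NC(=O)c1ccc(CSc2ccc(Cl)cc2)cc1`: "not determined" (no result reported)

Compound 3 has no place on this scale, because its entry reads "not determined" (no result reported). It therefore gives no starting number for the next compound.

Compound 4 `Cc1cc(C)cc(SCc2ccc(C(=O)Nc3ccccc3N)cc2)c1` differs from compound 3 by one change, 3,5-dimethylphenyl in place of 4-chlorophenyl on a sulfur.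

Among the measured compounds shown here, no measured step covers this exact swap. The closest evidence is the other change made on the sulfur, 4-fluorophenyl in place of phenethyl, which gave a 1.2-fold higher number from compound 1 to compound 2 (0.07 log units; within the scatter). That step is small and stays within the scatter, so the two measured compounds offer no sign of a large effect from changing this group. With no value for compound 3, no direction can be assigned to the step, and the estimate has to lean on compound 1 and compound 2 together.

In this assay, compound 4 is expected to give about 5000 nM, with an estimated range from 2000 nM to 12000 nM.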

Compound 4, half-maximal inhibitory concentration: 2760 nM
The estimate for compound 4 lay 1.8-fold (0.26 log units) above the measured number, and the stated range covers the measured number.
By their numbers in this assay, from the lowest: compounds 4, 1 and 2 (each within the scatter of the next, the first and the last beyond it).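

In this assay, changing the group on the sulfur now gives its first step beyond the usual scatter: 3,5-dimethylphenyl in place of 4-fluorophenyl gives a 2.1-fold lower number from compound 2 to compound 4 (0.32 log units; beyond the scatter), a modest shift. In place of phenethyl, the same group gives a 1.8-fold lower number from compound 1 to compound 4 (0.25 log units; within the scatter), which stays within the scatter, so among these three groups the position has so far produced only small differences. Compound 3 has no number, so the step from it to compound 4 cannot be read, and nothing available here explains the difference between compound 2 and compound 4.

Still open, from the compounds shown here alone, is how the number would respond to an amine, a carboxylic acid or a longer carbon chain on the sulfur. Also open, going by these compounds, is whether a phenyl ring carrying a single methyl would match 3,5-dimethylphenyl.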